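Taking the side chain off compound 2

The compounds below may be only part of what the source reports. "The series", "measured", "known", "first", "only" and "open" are said of these compounds alone.

Compound 1 `CN1CCN(CCCn2nc(C3=C(c4cn(C)c5ccccc45)C(=O)NC3=O)c3cccnc32)CC1`: 46700 nM
Compound 2 `CN(C)CCCn1nc(C2=C(c3cn(C)c4ccccc34)C(=O)NC2=O)c2cccnc21`: 50400 nM

Going by the values given here, in a functional assay on K562 cells (Homo sapiens) for antiproliferative activity, read by MTT assay, with a stated time of 48 h (a lower number here means a stronger inhibitor, a higher number a weaker inhibitor), compound 2 stands level with compound 1, the only other compound measured. Among the compounds with values here, the one measured step, a 1.1-fold higher number from compound 1 to compound 2 (0.03 log units; within the scatter), changed only the amine at the end of the chain. Compound 3 `Cn1cc(C2=C(c3n[nH]c4ncccc34)C(=O)NC2=O)c2ccccc21` has hydrogen in place of 3-(dimethylamino)propyl on an aromatic nitrogen. No measurement shows the whole chain removed, so that step bears on this change only weakly. No clear direction, and no shift beyond the scatter, is expected in this assay, though the uncertainty is wide. The expected change is a 1.3-fold lower number from compound 2 to compound 3 (0.10 log units; within the scatter). Compound 3 is estimated at 40000 nM, with a range of 12000 nM to 100000 nM.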

Compound 3, half-maximal inhibitory concentration: > 100000 nM
Compound 3: no number, only a limit; the forecaster's own chance of this, stated with the estimate: 25%; middle value at least 2.5-fold (0.39 log units) away from the limit.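

Compound 3 gives only a limit in this assay, not a number: the limit of > 100000 nM in this assay, at which 1 of the 3 values shown sits.

Putting hydrogen on the aromatic nitrogen gave an at least 1.9-fold higher number from compound 2 to compound 3 (0.29 log units; that floor lies within the scatter), and the same change from the larger chain gave an at least 2.1-fold higher number from compound 1 to compound 3 (0.33 log units; beyond the scatter). Where swapping the terminal amine had moved nothing beyond the scatter, losing the whole chain does so in the step from the piperazine compound, so this nitrogen's substituent matters more than the amine did.

From the compounds shown here alone, the true size of both steps stays open. So does whether a plain methyl group, a shorter chain or a chain ending in a carboxylic acid would keep the numbers of compound 1 and compound 2.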